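One fluorine, two positions, one antiproliferative read-out

The source may hold more compounds than are shown below. What is called first, only, known or untested is meant among the compounds shown, and "the series" means these compounds.

Compound 1 `Fc1cccc(NC(=S)N/N=C/c2ccc3ccccc3n2)c1` was examined in a functional assay on HT-29 cells (Homo sapiens) for antiproliferative activity, read by sulforhodamine B assay, with a stated time of 72 h (on this read-out lower numbers stand for stronger inhibition and higher numbers for weaker inhibition), where compound 1 gives 74700 nM. Among the two numbers recorded in this assay this is the highest. Its nearest neighbour is compound 2 `CC(C)c1cccc(C(C)C)c1NC(=S)N/N=C/c1ccc2ccccc2n1`, which in this assay gives 20700 nM, a difference that lies beyond the usual scatter of the measurement. Compound 3 `NC(=S)N/N=C/c1cc2cccnc2s1` is reported in this assay only as a limit, > 100000 nM, and it is the one result of the three that sits at the limit of > 100000 nM in this assay, at which 1 of the 3 values shown sits.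

Compound 4 `Fc1ccc(NC(=S)N/N=C/c2ccc3ccccc3n2)cc1` has not yet been measured in this assay. It differs from compound 1 in a single respect: 4-fluorophenyl in place of 3-fluorophenyl on an amide-type nitrogen. Among the compounds with values here, no pair of measured compounds differing in one place is available, so no measured step of this exact kind offers a guide. The change is expected to produce at most a small shift in this assay, in either direction and not beyond the scatter, and the expected step is a 1.2-fold lower number from compound 1 to compound 4 (0.10 log units; within the scatter). Compound 4 is accordingly estimated to give about 60000 nM in this assay, with a plausible range from 25000 nM to 150000 nM.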

Compound 4, half-maximal inhibitory concentration: 28500 nM
Estimate against measurement, compound 4: 2.1-fold (0.32 log units) above; measured number inside the range.
By their numbers in this assay, from the lowest: compounds 2 and 4 (each within the scatter of the next); then compound 1. At a limit, above all of these: compound 3.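

Within the data shown here, exchanging 3-fluorophenyl for 4-fluorophenyl on the amide-type nitrogen whose other neighbour is the thiocarbonyl carbon is the first change in one place that can be read in this assay, and it gives a 2.6-fold lower number from compound 1 to compound 4 (0.42 log units; beyond the scatter) with the atoms of the compound unchanged. The earlier compounds shown here offered no such pair, so they could not show that this phenyl group responds to where its fluorine stands, and although the step is modest, it exceeds the usual scatter of the measurement. Nothing given here accounts for why the number moves with this change.

Going by these compounds, this single pair sets no trend, and it remains open whether a chlorine, a methoxy group or an amine in place of the fluorine on this phenyl ring would give a number of the same order as those of the two fluorinated compounds. Also open, on these data alone, is what a carboxylic acid or a longer alkyl chain at this place would do in this assay, and whether the step between the two fluorophenyl groups would hold on any other core.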